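A Second Chloro on the Benzyl Ring of a Sulfone

This account rests on a few compounds, and the source may have more. Where it says the series, first, only, none or still open, it means among the compounds named here.

compound 1 `CCOC(=O)C1=CCCCC1S(=O)(=O)Cc1ccccc1Cl` — 14 nM; 1200 nM; 11 nM (3 entries)
compound 2 `CCOC(=O)C1=CCCCC1S(=O)(=O)Cc1cccc(Cl)c1` — 14 nM

In a functional assay on RAW264.7 cells (Mus musculus), read by fluorescence (on this read-out higher numbers stand for weaker inhibition and lower numbers for stronger inhibition), compound 1 `CCOC(=O)C1=CCCCC1S(=O)(=O)Cc1ccccc1Cl` gives 14 nM; 1200 nM; 11 nM (3 entries), three entries that spread widely, as the several entries of compound 1 in this assay, 14 nM; 1200 nM; 11 nM (3 entries) shows. Compound 2 `CCOC(=O)C1=CCCCC1S(=O)(=O)Cc1cccc(Cl)c1` gives 14 nM in this assay, the only number shown for it; a further entry for compound 2 carries no single number. Compound 3 `CCOC(=O)C1=CCCCC1S(=O)(=O)Cc1cccc(Cl)c1Cl` differs from compound 2 by chloro in place of hydrogen on an aromatic carbon. Going by the values given here, no measured pair shows this change, so no step beyond the scatter in this assay, in either direction, is expected. Compound 3 is expected at 15 nM, between 5 nM and 60 nM. This expectation amounts to a step of a 1.1-fold higher number from compound 2 to compound 3 (0.03 log units; within the scatter), within the scatter.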

Compound 3, half-maximal inhibitory concentration: 65 nM
Compound 3: the middle estimate sits 4.3-fold (0.64 log units) below what was measured; measured number above the stated range.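

Chloro in place of hydrogen on this aromatic carbon, ortho to a chloro group, is not a silent change in this assay: the pair gives a 4.6-fold higher number from compound 2 to compound 3 (0.67 log units; beyond the scatter), meaning weaker inhibition. Going by these compounds alone, this is the first measured pair to give a step at this position on the ring. The size of that step still needs caution, since entries in this assay can spread widely: the several entries of compound 1 in this assay, 14 nM; 1200 nM; 11 nM (3 entries)

The compounds shown leave open whether a fluoro, methyl or methoxy group on this carbon would give a similar step. They also leave open whether a repeat of compound 3 would hold its value.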